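Shortening the amine on the side chain of compound 2

The compounds below may be only part of what the source reports. "The series", "measured", "known", "first", "only" and "open" are said of these compounds alone.

For the measured compounds named here, compound 2 `CCCN(CCC)CCNc1nnc(-c2ccccc2)cc1C` gives 2 mg/kg in a functional assay on the whole organism with Mus musculus as the target (on this read-out higher numbers stand for an effect only at larger amounts of compound and lower numbers for an effect already at smaller amounts), the only number so far. Compound 1 `CCN(CC)CCNc1nnc(-c2ccccc2)cc1C` reaches only a limit of the assay in this assay, > 10 mg/kg, as noted in the limit of > 10 mg/kg in this assay, at which 1 of the 2 values shown sits. Going by the values given here, the one measured step, an at least 5.0-fold lower number from compound 1 to compound 2 (0.69 log units; beyond the scatter), shows that larger alkyl groups on the chain nitrogen gave the lower number. Compound 3 `Cc1cc(-c2ccccc2)nnc1NCCN` carries the change (amino in place of dipropylamino on a saturated chain carbon, two bonds along the chain from a nitrogen on an aromatic ring), which moves in the opposite direction from that step, so a higher number is expected for compound 3, estimated as a 5.0-fold higher number from compound 2 to compound 3 (0.70 log units; beyond the scatter). Compound 3 is expected to give about 10 mg/kg, within 3 mg/kg to 30 mg/kg, with a fair chance of only a limit.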

Compound 3, minimum effective dose: 0.5 mg/kg
Beside the measured number, compound 3's estimate is 20-fold (1.30 log units) above it; the measured number lies below the stated range.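

In this assay, amino in place of dipropylamino on this saturated chain carbon gives a 4.0-fold lower number from compound 2 to compound 3 (0.60 log units; beyond the scatter), so the number does not simply fall as the alkyl groups on the chain nitrogen grow. Amino in place of diethylamino gives an at least 20-fold lower number from compound 1 to compound 3 (1.30 log units; beyond the scatter). Compound 1 stands only at a limit of the assay: the limit of > 10 mg/kg in this assay, at which 1 of the 3 values shown sits.

Going by these compounds, how a single small alkyl group, as in methylamino, or a ring amine such as piperidine would read at this place remains open. So does the effect of a longer chain carrying the amino group.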